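Nitro in Place of Chloro: Expecting Compound 4

A few compounds are considered here, and "the series" means these few. Any claim that something is new, unique, unknown or untested is made for them only; others in the source may bear on it.

In a functional assay on HCT-116 cells (Homo sapiens) for antiproliferative activity, read by MTT assay, with a stated time of 48 h (on this read-out higher numbers stand for weaker inhibition and lower numbers for stronger inhibition), compound 3 `N#CC1=C(N)Oc2c(N)cc3nc4ccccc4nc3c2C12C(=O)N(Cc1cnnn1-c1ccc(Cl)cc1Cl)c1ccccc12` gives only a limit, > 50000 nM. Compound 1 `Cc1cccc(-n2nncc2CN2C(=O)C3(C(C#N)=C(N)Oc4c(N)cc5nc6ccccc6nc5c43)c3ccccc32)c1` also sits at a limit, > 50000 nM. the limit of > 50000 nM in this assay, at which 2 of the 3 values shown sit, marks where both stand. Compound 2 `N#CC1=C(N)Oc2c(N)cc3nc4ccccc4nc3c2C12C(=O)N(Cc1cnnn1-c1ccccc1Br)c1ccccc12` gives a number, 12400 nM. For the measured compounds named here, two measured steps touch the group on the aromatic nitrogen: an at least 4.0-fold lower number from compound 1 to compound 2 (0.60 log units; beyond the scatter), and an at least 4.0-fold higher number from compound 2 to compound 3 (0.60 log units; beyond the scatter), while a step that the two limits leave unreadable from compound 1 to compound 3 cannot be read between two limits. Compound 4 `N#CC1=C(N)Oc2c(N)cc3nc4ccccc4nc3c2C12C(=O)N(Cc1cnnn1-c1ccc(Cl)cc1[N+](=O)[O-])c1ccccc12` differs from compound 3 by nitro in place of chloro on an aromatic carbon. Going by the values given here, no measured step tests a nitro group, so the direction of the change is unknown. Because an at least 4.0-fold higher number from compound 2 to compound 3 (0.60 log units; beyond the scatter) ends at the limit, compound 4 is expected to remain weak, and an at least 1.1-fold lower number from compound 3 to compound 4 (0.04 log units; that floor lies within the scatter) is expected to stay within the scatter. Compound 4 is estimated at 45000 nM, between 12000 nM and 120000 nM.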

Compound 4, half-maximal inhibitory concentration: 28700 nM
Estimate against measurement, compound 4: 1.6-fold (0.20 log units) above; the measured number falls inside the stated range.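

In this assay, nitro on this aromatic carbon, ortho to a large group, gives a measurable number where chloro gave only a limit, with an at least 1.7-fold lower number from compound 3 to compound 4 (0.24 log units; that floor lies within the scatter). Against 2-bromophenyl, however, 4-chloro-2-nitrophenyl still inhibits less strongly, with a 2.3-fold higher number from compound 2 to compound 4 (0.36 log units; beyond the scatter). Against 3-methylphenyl, the same group reads an at least 1.7-fold lower number from compound 1 to compound 4 (0.24 log units; that floor lies within the scatter).

Going by these compounds, two of these steps start from a limit and not from a number: the limit of > 50000 nM in this assay, at which 2 of the 4 values shown sit. Whether an amine or a carboxylic acid in place of the nitro group would bring stronger inhibition remains open.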